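Acetyl for Ethylsulfonyl on a Ring Nitrogen

This account rests on a few compounds, and the source may have more. Where it says the series, first, only, none or still open, it means among the compounds named here.

Compound 1 `Oc1cccc2c1CCCC2c1c[nH]cn1` gives 30.9 nM in an assay on isolated protein for binding affinity to Alpha-1D adrenergic receptor (Rattus norvegicus), read by radioligand binding; a higher number here means a weaker inhibitor, a lower number a stronger inhibitor.
Compound 2 `CCCS(=O)(=O)Nc1cccc2c1CCCC2c1c[nH]cn1` gives < 10000 nM in this assay, and this value is a limit of the assay rather than a number.
Compound 3 `CCS(=O)(=O)Nc1cccc2c1CCCC2c1c[nH]cn1` gives 1070 nM in this assay.

Compound 3 stands highest of the two readable numbers; its nearest neighbour is compound 1, and the step between them was a 35-fold higher number from compound 1 to compound 3 (1.54 log units; beyond the scatter), brought about by (ethylsulfonyl)amino in place of hydroxy on an aromatic carbon. The steps a step that the limit leaves unreadable from compound 1 to compound 2 and a step that the limit leaves unreadable from compound 2 to compound 3 cannot be sized because of the limit of < 10000 nM in this assay, at which 1 of the 3 values shown sits.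

Compound 4 `CC(=O)Nc1cccc2c1CCCC2c1c[nH]cn1` differs from compound 3 by acetyl in place of ethylsulfonyl on a nitrogen on an aromatic ring. Going by the values given here, no measured pair sets acetyl against ethylsulfonyl on this nitrogen, so the change is not directly covered. Among the compounds with values here, the only sized step, a 35-fold higher number from compound 1 to compound 3 (1.54 log units; beyond the scatter), shows that exchanging the hydroxy of compound 1 for a sulfonylated amine raised the number a great deal; compound 4 keeps the amine but swaps the ethylsulfonyl for acetyl. Some recovery toward the hydroxy compound is plausible, yet unproven, so a moderate move downward is expected, with wide uncertainty. Compound 4 is expected to give 400 nM in this assay, with a range from 80 nM to 2000 nM. That estimate amounts to an expected step of a 2.7-fold lower number from compound 3 to compound 4 (0.43 log units; beyond the scatter).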

Compound 4, inhibition constant: < 10000 nM
Compound 4: no number, only a limit (the forecaster's own chance of this, stated with the estimate: 5%); the middle value lies beyond the limit too.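

Compound 4 gives < 10000 nM in this assay, which is a limit of the assay and not a number. Its steps to compound 1, compound 2 and compound 3 therefore cannot be read: the limit of < 10000 nM in this assay, at which 2 of the 4 values shown sit.

The compounds shown leave open how acetyl and ethylsulfonyl on this nitrogen compare, and how far compound 2 and compound 4 lie from compound 3.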